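A few compounds are considered here, and "the series" means these few. Any claim that something is new, unique, unknown or untested is made for them only; others in the source may bear on it.

Two compounds have been measured in a functional assay on SGC-7901 cells (Homo sapiens) for inhibition, read by MTT assay, with a stated time of 24 h; on this read-out lower numbers stand for stronger inhibition and higher numbers for weaker inhibition:

compound 1, `CC1(C)[C@H]2CC[C@]1(C)N(Cc1cn(-c3cccc(F)c3)nn1)C(=O)C2`, 530 nM
compound 2, `CC1(C)[C@H]2CC[C@]1(C)N(Cc1cn(-c3ccccc3F)nn1)C(=O)C2`, 300 nM

Compound 1 sits at one end of the two numbers shown, yet the step of a 1.8-fold lower number from compound 1 to compound 2 (0.25 log units; within the scatter) lies within the scatter, so neither compound can be called stronger in this assay . Compound 3, `Cc1cccc(-n2cc(CN3C(=O)C[C@@H]4CC[C@@]3(C)C4(C)C)nn2)c1`, is not yet measured. It differs from compound 1 thus: methyl in place of fluoro on an aromatic carbon. For the measured compounds named here, the only measured step, a 1.8-fold lower number from compound 1 to compound 2 (0.25 log units; within the scatter), concerns 2-fluorophenyl in place of 3-fluorophenyl on an aromatic nitrogen and bears on this change only indirectly, indicating that a modest alteration on that ring left the number within the scatter. Going by the values given here, no measured step exchanges a fluoro for a methyl. The step of a 1.1-fold lower number from compound 1 to compound 3 (0.03 log units; within the scatter) is therefore expected to be small, in no certain direction. Compound 3 is estimated at 500 nM, with a range from 200 nM to 1300 nM.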

Compound 3, half-maximal inhibitory concentration: 410 nM
Compound 3: middle estimate off by 1.2-fold (0.09 log units), on the high side, within the range that was stated.
By their numbers in this assay, from the lowest: compounds 2, 3 and 1 (each within the scatter of the next).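

In this assay, methyl in place of fluoro on an aromatic carbon, meta to a large group, gives a 1.3-fold lower number from compound 1 to compound 3 (0.11 log units; within the scatter); this is a direct exchange of the group at this position, and it cannot be told apart from no change. Set against the other fluorinated compound, the step is a 1.4-fold higher number from compound 2 to compound 3 (0.14 log units; within the scatter), so the 3-methylphenyl, 3-fluorophenyl and 2-fluorophenyl compounds cannot be separated on these numbers. No supporting data bear on this result.

The compounds shown leave open whether a different group at this position, such as an amine, a carboxylic acid or a methoxy group, would move the number beyond the scatter. They also leave open how methyl would read in the place that fluoro holds in compound 2.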